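The source may hold more compounds than are shown below. What is called first, only, known or untested is meant among the compounds shown, and "the series" means these compounds.

Working notes on the series. Going by the values given here, the three measured members share one core; compound 1 `Nc1cc(N)c2nc(-c3ccccc3)c(Oc3ccc(Cl)c(Cl)c3)nc2c1` carries a 3,4-dichlorophenoxy group, compound 2 `CCOC(=O)[C@H](CCC(=O)O)NC(=O)c1ccc(CNc2nc3cc(N)cc(N)c3nc2-c2ccccc2)cc1` a glutamate-bearing benzylamino arm, and compound 3 `CCOC(=O)[C@H](CCC(=O)O)NC(=O)c1ccc(Sc2nc3cc(N)cc(N)c3nc2-c2ccccc2)cc1` the corresponding thioether arm. In a functional assay on NCI-H460 cells (Homo sapiens) for inhibition, read by sulforhodamine B assay, with a stated time of 48 h (a lower number here means a stronger inhibitor of growth, a higher number a weaker inhibitor of growth), compound 1 gives 18200 nM, compound 2 gives 31600 nM and compound 3 gives 27500 nM. Compound 1 has the lowest of the three numbers, but its gaps to compound 3 and to compound 2 both lie within the usual scatter, so no ordering among the three can be claimed; all three sit in the same weak range.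

Compound 4 `Nc1cc(N)c2nc(-c3ccccc3)c(NCc3ccc(F)cc3)nc2c1` is not yet measured. It differs from compound 1 in one place: (4-fluorobenzyl)amino in place of 3,4-dichlorophenoxy on an aromatic carbon. Among the compounds with values here, no step between measured compounds isolates this kind of exchange, so nothing in the data points to a direction; compound 2, which also carries a benzylamino attachment at that position, gives a number within the scatter of compound 1. On that basis a step of a 1.2-fold higher number from compound 1 to compound 4 (0.08 log units; within the scatter) is expected, that is, none beyond the scatter. Compound 4 is therefore estimated at 22000 nM in this assay, with a likely range from 8000 nM to 60000 nM.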

Compound 4, concentration for 50% growth inhibition: 4070 nM
The estimate for compound 4 lay 5.4-fold (0.73 log units) above the measured number; measured number outside the range, below it.
By their numbers in this assay, from the lowest: compound 4; then compounds 1, 3 and 2 (each within the scatter of the next).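

In this assay, going by these compounds alone, the aromatic carbon next to the ring nitrogen and ortho to a phenyl group proves sensitive to its substituent: (4-fluorobenzyl)amino in place of 3,4-dichlorophenoxy gives a 4.5-fold lower number from compound 1 to compound 4 (0.65 log units; beyond the scatter), the only step beyond the scatter. The two groups match in heavy-atom count and each holds one six-membered aromatic ring, so the step comes with no change in either count, while the entering group adds a hydrogen-bond donor and differs in its link and its halogens. No available data bear on the cause of this step.

Which of these differences carries the step remains open. A plain benzylamino, a benzyloxy or a 4-fluorophenoxy group at this position would separate the link from the halogens, and a 2-phenylethylamino group would test a longer chain.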